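Pyridin-2-yl to 5-methylthiophen-2-yl in a cytotoxicity series

The source may report more compounds than this note shows. Statements on the series, on what has been measured and on what is new or still open speak of the compounds shown alone.

In a functional assay on MCF7 cells (Homo sapiens) for cytotoxicity, read by MTT assay, with a stated time of 48 h (on this read-out lower numbers stand for stronger inhibition and higher numbers for weaker inhibition), compound 1 (`O=C1/C(=C\c2cccc(Cl)c2)S/C(=N/c2ccccc2)N1Cc1ccncc1`) gives 29800 nM, and compound 2 (`O=C1/C(=C\c2ccccn2)S/C(=N/c2ccccc2)N1Cc1ccncc1`) gives 21100 nM. Among the compounds with values here, the one measured step, a 1.4-fold lower number from compound 1 to compound 2 (0.15 log units; within the scatter), lies within the scatter, so compound 2 cannot be told apart from compound 1 on these two numbers. Compound 3 (`Cc1ccc(/C=C2/S/C(=N/c3ccccc3)N(Cc3ccncc3)C2=O)s1`) keeps the core of compound 2 and alters one group: 5-methylthiophen-2-yl in place of pyridin-2-yl on a double-bonded chain carbon bound to a double-bonded ring carbon. The exchange falls on a double-bonded chain carbon bound to a double-bonded ring carbon, the same place as the measured step. Within the data shown here, no measured compound carries 5-methylthiophen-2-yl, so that step, which took 3-chlorophenyl to pyridin-2-yl, is the only guide. On that evidence, no shift beyond the scatter is expected in this assay, and the estimated change is a 1.2-fold lower number from compound 2 to compound 3 (0.07 log units; within the scatter). For compound 3 the estimated value is 18000 nM, with an expected range of 7000 nM to 45000 nM.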

Compound 3, half-maximal inhibitory concentration: 28700 nM
For compound 3 the middle estimate is 1.6-fold (0.20 log units) below the measured one; measured number inside the range.
By their numbers in this assay, from the lowest: compounds 2, 3 and 1 (each within the scatter of the next).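

In this assay the place on a double-bonded chain carbon bound to a double-bonded ring carbon now carries a third group, and the exchange gives a 1.4-fold higher number from compound 2 to compound 3 (0.13 log units; within the scatter) and also a 1.0-fold lower number from compound 1 to compound 3 (0.02 log units; within the scatter) for the swap of 5-methylthiophen-2-yl with 3-chlorophenyl. All three groups at this place, 3-chlorophenyl, pyridin-2-yl and 5-methylthiophen-2-yl, thus lie within the scatter of one another, and even going from a six-membered to a five-membered aromatic ring, with sulfur entering and nitrogen leaving, does not set compound 3 apart from compound 2. No evidence at hand bears on why these numbers stay together.

Open, from the compounds shown here alone, is whether a group of another kind at this place, such as an amine, a carboxylic acid or a longer chain, would give a step beyond the scatter. Also open, going by these compounds, is whether any such group would move the number in either direction on this core.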